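From 4-methylbenzyl to 2,4,6-trimethylbenzyl in compound 4

A few compounds are considered here, and "the series" means these few. Any claim that something is new, unique, unknown or untested is made for them only; others in the source may bear on it.

Among the compounds with values here, in a functional assay on PC-3 cells (Homo sapiens) for cytotoxicity, read by MTT assay (a higher number here means a weaker inhibitor, a lower number a stronger inhibitor), compound 1 (`COc1ccc2cc([C@H](C)c3nnc(SCc4ccc(C)cc4)n3-c3ccc(F)cc3)ccc2c1`) gives 229000 nM as the highest number of the three compounds measured so far. Compound 2 (`COc1ccc2cc([C@H](C)c3nnc(SCc4ccccc4)n3-c3ccc(Cl)cc3)ccc2c1`) gives 14200 nM in the same test, and compound 3 (`COc1ccc2cc([C@H](C)c3nnc(SCc4ccc(C)cc4)n3-c3ccc(Cl)cc3)ccc2c1`) gives 8400 nM there.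

The unmeasured compound 4 (`COc1ccc2cc([C@H](C)c3nnc(SCc4c(C)cc(C)cc4C)n3-c3ccc(F)cc3)ccc2c1`) has 2,4,6-trimethylphenyl in place of 4-methylphenyl on a saturated chain carbon bound to a sulfur.

The closest evidence is a single methyl in place of hydrogen on an aromatic carbon, which gives a 1.7-fold lower number from compound 2 to compound 3 (0.23 log units; within the scatter) as a small step. The chloro in place of fluoro swap gives a 27-fold lower number from compound 1 to compound 3 (1.44 log units; beyond the scatter) as a large step, but it lies elsewhere in the molecule and says nothing direct about this change. Within the data shown here, no measured pair tests the 2,4,6-trimethylphenyl group itself, so only a small step is expected in this assay, slightly towards a lower number.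

The expected change is a 1.5-fold lower number from compound 1 to compound 4 (0.18 log units; within the scatter) and no more.

For compound 4 the estimate is 150000 nM with an expected range of 30000 nM to 450000 nM in this test.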

Compound 4, half-maximal inhibitory concentration: 43300 nM
Compound 4: middle estimate off by 3.5-fold (0.54 log units), on the high side; low and high end bracket the measured number.
By their numbers in this assay, from the lowest: compounds 3 and 2 (each within the scatter of the next); then compound 4; then compound 1.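

In this assay, the change from 4-methylphenyl to 2,4,6-trimethylphenyl on a saturated chain carbon bound to a sulfur gives a 5.3-fold lower number from compound 1 to compound 4 (0.72 log units; beyond the scatter), so this part of the molecule can shift the number measurably. The earlier step at this part, methyl in place of hydrogen, gave a 1.7-fold lower number from compound 2 to compound 3 (0.23 log units; within the scatter), which could not separate a real change from ordinary scatter, and it was read with chloro rather than fluoro on the other aromatic ring. Nothing measured here accounts for the step from 4-methylphenyl to 2,4,6-trimethylphenyl.

On these data alone, whether the same swap would lower the number in the chloro compound 3 remains open. So does how an amine, a carboxylic acid or a longer chain would behave at this place.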